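The compounds below may be only part of what the source reports. "The series", "measured", "known", "first", "only" and "open" are said of these compounds alone.

Of the compounds shown here, two that share one core have been measured in a functional assay on A549 cells (Homo sapiens) for antiproliferative activity, read by MTT assay, with a stated time of 72 h; on this read-out lower numbers stand for stronger inhibition and higher numbers for weaker inhibition. Compound 1 (`CC/C=C/C(=O)Nc1cccc(Oc2nc(Nc3cccc(OC)c3)nc3c2CSCC3)c1`) gives 17200 nM, and compound 2 (`COc1cccc(Nc2nc3c(c(Oc4cccc(NC(=O)C=C(C)C)c4)n2)CSCC3)c1`) gives 19800 nM. Compound 2 therefore stands level with compound 1, since the step between them, a 1.2-fold higher number from compound 1 to compound 2 (0.06 log units; within the scatter), does not separate the two. That step places 2-methylprop-1-en-1-yl in place of but-1-en-1-yl on a carbonyl carbon.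

Compound 3 (`COc1ccc(Nc2nc3c(c(Oc4cccc(NC(=O)C=C(C)C)c4)n2)CSCC3)cn1`) keeps that carbonyl side of compound 2 and changes another part of the molecule: 6-methoxypyridin-3-yl in place of 3-methoxyphenyl on a nitrogen on an aromatic ring. It has 6-methoxypyridin-3-yl in place of 3-methoxyphenyl on a nitrogen on an aromatic ring. Among the compounds with values here, no measured step touches this place, so the only step available says nothing direct about the new ring, and the data give no direction for the change. With no evidence for a shift, the expectation in this assay is no change beyond the scatter, though with wide uncertainty. The expected change is a 1.1-fold lower number from compound 2 to compound 3 (0.04 log units; within the scatter). For compound 3 the estimated value is 18000 nM, with an expected range from 7000 nM to 45000 nM.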

Compound 3, half-maximal inhibitory concentration: 16800 nM
Compound 3: middle estimate off by 1.1-fold (0.03 log units), on the high side, within the range that was stated.
By their numbers in this assay, from the lowest: compounds 3, 1 and 2 (each within the scatter of the next).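

Within the data shown here, this is the first step at the position on a nitrogen on an aromatic ring, as the earlier step touched only the carbonyl side. In this assay, placing 6-methoxypyridin-3-yl in place of 3-methoxyphenyl gives a 1.2-fold lower number from compound 2 to compound 3 (0.07 log units; within the scatter) and so does not separate the two compounds. The entering ring carries a ring nitrogen and one more hydrogen-bond acceptor than the leaving ring, with the same count of heavy atoms, yet this exchange leaves compound 3 level with compound 2, and no supporting measurement bears on this result.

Going by these compounds, whether a different group on that ring, such as an amine, a carboxylic acid or a longer alkoxy chain in place of the methoxy group, would move the number beyond the scatter remains open. Among these compounds, it is also open whether the same ring exchange would read alike with but-1-en-1-yl on the carbonyl carbon, as this step is seen only with 2-methylprop-1-en-1-yl there.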